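The compounds below may be only part of what the source reports. "The series", "measured", "known", "first", "only" and "open" are said of these compounds alone.

Working notes on the shared core of compound 1 `COc1ccc(CNC(=O)c2nc(-c3ccc(F)cc3)n(CC[C@@H](O)C[C@@H](O)CC(=O)O)c2C2CC2)cc1F`, compound 2 `O=C(O)C[C@H](O)C[C@H](O)CCn1c(-c2ccc(F)cc2)nc(C(=O)NCc2ccc(F)c(F)c2)c1C1CC1` and compound 3 `O=C(O)C[C@H](O)C[C@H](O)CCn1c(-c2ccc(F)cc2)nc(C(=O)NCc2ccc(F)cc2)c1C1CC1`, which differ only in the aryl of the benzylamide. In an assay on microsomes from liver for inhibition of 3-hydroxy-3-methylglutaryl-coenzyme A reductase (Rattus norvegicus), read by scintillation counting, with stated times of 0.5 h and 0.75 h (a lower number here means a stronger inhibitor, a higher number a weaker inhibitor), compound 1 gives 3.7 nM, compound 2 gives 1.2 nM and compound 3 gives 3.4 nM, the second highest of the three numbers. The measured steps are a 3.1-fold lower number from compound 1 to compound 2 (0.49 log units; beyond the scatter), a 2.8-fold higher number from compound 2 to compound 3 (0.45 log units; beyond the scatter) and a 1.1-fold lower number from compound 1 to compound 3 (0.04 log units; within the scatter). Compound 4 `COc1ccccc1CNC(=O)c1nc(-c2ccc(F)cc2)n(CC[C@@H](O)C[C@@H](O)CC(=O)O)c1C1CC1` differs from compound 3 by 2-methoxyphenyl in place of 4-fluorophenyl on a saturated chain carbon bound to an amide-type nitrogen. The methoxy-bearing aryl of compound 1 and the 4-fluorophenyl of compound 3 sit within the scatter of each other, while the fluoro-for-methoxy exchange from compound 1 to compound 2 was only modest. Compound 4 is therefore expected to give 5 nM, in the range 2 nM to 15 nM. The expected step of a 1.5-fold higher number from compound 3 to compound 4 (0.17 log units; within the scatter) is small, if anything toward a higher number.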

Compound 4, half-maximal inhibitory concentration: 7 nM
Estimate against measurement, compound 4: 1.4-fold (0.15 log units) below; the range from low to high includes it.
By their numbers in this assay, from the lowest: compound 2; then compounds 3, 1 and 4 (each within the scatter of the next, the first and the last beyond it).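

In this assay, the 2-methoxyphenyl on a saturated chain carbon bound to an amide-type nitrogen gives up only modest ground to the fluorinated aryls, with a 2.1-fold higher number from compound 3 to compound 4 (0.31 log units; beyond the scatter) and a 5.8-fold higher number from compound 2 to compound 4 (0.77 log units; beyond the scatter). Against the other methoxy-bearing aryl, a 1.9-fold higher number from compound 1 to compound 4 (0.28 log units; within the scatter), so compound 1 and compound 4 are not told apart. Nothing measured here accounts for these steps.

Compound 4 gains the methoxy and loses the fluoro in one change, so the two stay unseparated. As far as these compounds go, how a dimethylamino group or a carboxylic acid on this aryl would read also remains open.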